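The compounds below may be only part of what the source reports. "The series", "measured", "known", "first", "only" and "open" are said of these compounds alone.

Measured so far:
compound 1, `CC(=O)NCC#CCn1ccnc1`, gives in a functional assay on the whole organism for agonist activity, with Mus musculus as the target (a lower number here means that less compound is needed, a higher number that more compound is needed for the effect), a limit of > 100 mg/kg
compound 2, `CC(=O)NCC#CCn1cncc1C`, gives in this assay a limit of > 100 mg/kg
compound 3, `COC(=O)N(C)CC#CCn1ccnc1`, gives in this assay 4.5 mg/kg

Compound 1 and compound 2 share a core and differ by methyl in place of hydrogen on an aromatic carbon. The step that the two limits leave unreadable from compound 1 to compound 2 tells nothing about its size, since each value is a limit of the assay. For the measured compounds named here, compound 3 supplies the only number; how its core differs from that of compound 1 is not broken down here.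

Compound 4, `COC(=O)N(C)CC#CCn1cncc1C`, is not yet measured. It differs from compound 3 by methyl in place of hydrogen on an aromatic carbon. This is the same kind of change as from compound 1 to compound 2, though the surroundings are described differently: in one case the ring atom next to the place bears a large group, in the other a group of 8 heavy atoms.

Going by the values given here, no measured step gives the size of this change, so compound 4 is expected to stay near compound 3, at an estimated 6 mg/kg, within 2 mg/kg to 25 mg/kg, which would mean an expected step of a 1.3-fold higher number from compound 3 to compound 4 (0.12 log units; within the scatter). Because (the limit of > 100 mg/kg in this assay, at which 2 of the 3 values shown sit), there remains some chance that compound 4 also returns only a limit.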

Compound 4, dose for half-maximal effect: > 100 mg/kg
Compound 4 gave a limit, no number; the forecaster's own chance of this, stated with the estimate: 15%; at least 16-fold (1.22 log units) between middle value and limit.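

On the core of compound 3, methyl in place of hydrogen on an aromatic carbon brings an at least 22-fold higher number from compound 3 to compound 4 (1.34 log units; beyond the scatter) in this assay. The same change from compound 1 to compound 2 cannot be read, as both values are limits, so the series gives no second size to set beside this one and does not show whether the step carries over from one core to another. The step on the core of compound 3 is also open-ended, with its size set by where the assay stops: the limit of > 100 mg/kg in this assay, at which 3 of the 4 values shown sit.

As far as these compounds go, it remains open whether the rise belongs to the methyl as such or would also appear with another group in the same place, such as ethyl or a chlorine atom. Also open, from the compounds shown here alone, is how the same change would read on a further core, for instance one carrying a free amine where compound 3 has its carbonyl-bearing chain end.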